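This account rests on a few compounds, and the source may have more. Where it says the series, first, only, none or still open, it means among the compounds named here.

Measured so far:
compound 1 `O=C(/C(=C\c1ccc(Br)c(O)c1)S(=O)(=O)c1ccc(Br)cc1)c1ccc(Br)cc1`: 50000 nM
compound 2 `Cc1ccc(CS/C(=C/c2ccc(F)c([N+](=O)[O-])c2)C(=O)c2ccc(C(=O)O)cc2)cc1`: 1000 nM
compound 3 `COc1ccccc1/C=C(/SCc1ccccc1F)C(=O)c1ccc(Cl)cc1`: 10000 nM

The three measured compounds were tested in a functional assay on DU-145 cells (Homo sapiens) for inhibition, read by trypan blue exclusion, with a stated time of 96 h; on this read-out lower numbers stand for stronger inhibition of growth and higher numbers for weaker inhibition of growth. Compound 1 gives the highest of the three numbers, 50000 nM. Its nearest neighbour on the scale is compound 3, which gives 10000 nM, a gap that lies beyond the scatter, and the furthest is compound 2, which gives 1000 nM, also beyond the scatter. Compound 1 therefore stands as the weakest grower-inhibitor of the three.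

The next compound, compound 4 `COc1ccc(/C=C(\C(=O)c2ccc(Br)cc2)S(=O)(=O)c2ccc(Br)cc2)c(OC)c1`, differs from compound 1 in one place: 2,4-dimethoxyphenyl in place of 4-bromo-3-hydroxyphenyl on a double-bonded chain carbon bound to a double-bonded chain carbon. For the measured compounds named here, no measured pair shows this exact change, so its size cannot be read from the data. Given that every other measured compound sits below compound 1, a modest move toward lower numbers is expected for compound 4, though it may well remain within the scatter; the step from compound 1 is estimated as a 2.5-fold lower number from compound 1 to compound 4 (0.40 log units; beyond the scatter). Compound 4 is estimated at 20000 nM, with a range from 5000 nM to 80000 nM.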

Compound 4, concentration for 50% growth inhibition: 8000 nM
For compound 4 the middle estimate is 2.5-fold (0.40 log units) above the measured one; the measured number falls inside the stated range.
By their numbers in this assay, from the lowest: compound 2; then compounds 4 and 3 (each within the scatter of the next); then compound 1.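

For the compounds shown here, replacing 4-bromo-3-hydroxyphenyl with 2,4-dimethoxyphenyl on a double-bonded chain carbon bound to a double-bonded chain carbon gives the only one-place comparison so far, and in this assay it produces a 6.3-fold lower number from compound 1 to compound 4 (0.80 log units; beyond the scatter), showing that the group at this position can shift growth inhibition beyond the scatter. The change removes the bromine and the hydrogen-bond donor and adds a second oxygen, all in one step, so the shift cannot be divided among these differences. Nothing in the available data explains the shift.

The compounds shown leave open whether a single methoxy group or the loss of bromine alone would give a similar step. They also leave open how an amine or a nitrile on the same ring would compare.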